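This account rests on a few compounds, and the source may have more. Where it says the series, first, only, none or still open, it means among the compounds named here.

Compound 1 `COc1ccc2cc(CCCSc3nnnn3-c3ccccc3)oc(=O)c2c1`: in a functional assay on NCI-H460 cells (Homo sapiens) for antiproliferative activity, read by sulforhodamine B assay, with a stated time of 48 h (on this read-out lower numbers stand for stronger inhibition of growth and higher numbers for weaker inhibition of growth), compound 1 gives >= 250 ug/mL, a limit of the assay.
Compound 2 `COc1ccc2c(c1)C(=O)OC(CO)C2`: compound 2 gives >= 250 ug/mL, also a limit.
Compound 3 `COc1ccc2c(c1)C(=O)OC(CCCO)C2`: compound 3 gives 136 ug/mL.

Among the measured compounds shown here, compound 3 thus holds the only number in the set, the other two values being limits (the limit of >= 250 ug/mL in this assay, at which 2 of the 3 values shown sit). For the measured compounds named here, the single measured step, an at least 1.8-fold lower number from compound 2 to compound 3 (0.26 log units; that floor lies within the scatter), concerns a longer hydroxylated chain and lies within the scatter. Compound 4 `CCCCCOCCCC1Cc2ccc(OC)cc2C(=O)O1` differs from compound 3 by pentyl in place of hydrogen on an oxygen on a saturated carbon. Going by the values given here, no measured step touches this oxygen, so the available data give no direction beyond the scatter, and the expected step is a 1.4-fold lower number from compound 3 to compound 4 (0.13 log units; within the scatter). Compound 4 is therefore estimated at 100 ug/mL, with a range from 35 ug/mL to 250 ug/mL.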

Compound 4, concentration for 50% growth inhibition: 33.7 ug/mL
Beside the measured number, compound 4's estimate is 3.0-fold (0.47 log units) above it, and the stated range ends above it.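

Pentyl on the oxygen on a saturated carbon, which turns hydroxy into pentyloxy, gives in this assay a step beyond the scatter, a 4.0-fold lower number from compound 3 to compound 4 (0.61 log units; beyond the scatter), the first such step in the set. A free hydroxy at this place is therefore not needed for growth inhibition in compound 4. Among the compounds shown here, this is also the only step that joins two actual numbers, the other values being limits: the limit of >= 250 ug/mL in this assay, at which 2 of the 4 values shown sit.

From the compounds shown here alone, whether methoxy, a longer chain such as octyloxy, or an amine at this place would move the number further remains open.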